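The compounds below may be only part of what the source reports. "The series", "measured", "known", "first", "only" and "open" are said of these compounds alone.

Measured so far in a functional assay on HEL cells (Homo sapiens) for cytotoxicity, read by microscopy; a higher number here means that more compound is tolerated, a lower number that less compound is tolerated:
Compound 1 `COC(=O)CNC1=CS(=O)(=O)O[C@@]12[C@@H](CO[Si](C)(C)C(C)(C)C)O[C@@H](n1cc(C)c(=O)n(C)c1=O)[C@@H]2O[Si](C)(C)C(C)(C)C`: >= 400000 nM
Compound 2 `Cc1cn([C@@H]2O[C@H](CO[Si](C)(C)C(C)(C)C)[C@@]3(OS(=O)(=O)C=C3NC(N)=O)[C@H]2O[Si](C)(C)C(C)(C)C)c(=O)n(C)c1=O`: 16000 nM
Compound 3 `COC(=O)NC1=CS(=O)(=O)O[C@@]12[C@@H](CO[Si](C)(C)C(C)(C)C)O[C@@H](n1cc(C)c(=O)n(C)c1=O)[C@@H]2O[Si](C)(C)C(C)(C)C`: >= 50000 nM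

The value for compound 1 is a limit of the assay, not a number. The value for compound 3 is also such a limit. Compound 3 thus stands only as a limit, and one of the other values shown is a limit as well, so its exact place among the three cannot be fixed. Compound 4 `Cc1cn([C@@H]2O[C@H](CO[Si](C)(C)C(C)(C)C)[C@@]3(OS(=O)(=O)C=C3NC(=O)c3ccccc3)[C@H]2O[Si](C)(C)C(C)(C)C)c(=O)n(C)c1=O` differs from compound 3 in one place: phenyl in place of methoxy on a carbonyl carbon. Within the data shown here, no measured step puts phenyl in place of methoxy here. The nearest is an at least 3.1-fold higher number from compound 2 to compound 3 (0.49 log units; beyond the scatter), which changed the same carbonyl carbon. That step and the limit for compound 3 give little to go on, so a step of modest size in either direction, or none beyond the scatter, is expected: a number no higher from compound 3 to compound 4 (the limit leaves the size open). Compound 4 is expected to give 50000 nM in this assay, with a range from 10000 nM to 200000 nM.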

Compound 4, minimum cytotoxic concentration: >= 3200 nM
Compound 4 was reported as a limit (the forecaster's own chance of this, stated with the estimate: 50%); the middle value lies beyond the limit too.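

In this assay compound 4 gives >= 3200 nM, which is a limit, so its steps from compound 1, compound 2 and compound 3 cannot be read. Going by these compounds, the true size of the change from methoxy to phenyl stays open.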